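Series notes: removing the methyl from compound 3

The source may hold more compounds than are shown below. What is called first, only, known or untested is meant among the compounds shown, and "the series" means these compounds.

Compound 3 `Cc1ccc(-c2nn(-c3ccccc3)cc2C2CC(c3ccc(F)cc3)=NN2c2ccccc2)cc1` gives 110% in a functional assay on the whole organism (Tail) with Rattus norvegicus as the target, in the tail flick test, with a stated time of 60 min, at a dose of 25 mg/kg by the oral route (a higher number here means more inhibition at the dose given (going by the name of the read-out), a lower number less inhibition), the highest of the three numbers measured. Compound 2 `Fc1ccc(C2=NN(c3ccccc3)C(c3cn(-c4ccccc4)nc3-c3ccc(Cl)cc3)C2)cc1` gives 43% and compound 1 `CC(=O)N1N=C(c2ccc(F)cc2)CC1c1cn(-c2ccccc2)nc1-c1ccccc1` gives 35%, both lower than compound 3 beyond the scatter. Compound 4 `Fc1ccc(C2=NN(c3ccccc3)C(c3cn(-c4ccccc4)nc3-c3ccccc3)C2)cc1` has not yet been measured. The change from compound 3 to compound 4 is hydrogen in place of methyl on an aromatic carbon.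

Going by the values given here, only one measured step touches this position: a number 67 percentage points higher from compound 2 to compound 3 (beyond the scatter). Among the compounds with values here, that step put methyl in place of chloro, not hydrogen, so it is related rather than the same change; no pair among the measured compounds isolates methyl against hydrogen at this carbon. Within the data shown here, still, both compounds that lack the methyl, compound 1 and compound 2, sit far below compound 3, so a large drop is the expected direction for compound 4, with wide uncertainty because only the step of a number 67 percentage points higher from compound 2 to compound 3 (beyond the scatter) speaks to it.

The expected step is a number 60 percentage points lower from compound 3 to compound 4 (beyond the scatter). Compound 4 is estimated at 50%, within a range from 15% to 95%.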

Compound 4, a percentage reported as inhibition, in the whole organism at one dose (the size of the read-out at that dose, not a potency): 35%
Beside the measured number, compound 4's estimate is 15 percentage points above it; measured number inside the range.
By their numbers in this assay, from the lowest: compounds 1, 4 and 2 (each within the scatter of the next); then compound 3.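

In this assay, going by these compounds alone, the 4-methylphenyl to phenyl change gives the first direct reading of methyl against hydrogen at this carbon, with a number 75 percentage points lower from compound 3 to compound 4 (beyond the scatter) for the change. Chloro and hydrogen on the same carbon are not separated, with a number 8 percentage points lower from compound 2 to compound 4 (within the scatter) for that change, so among these three groups only methyl stands apart, a pattern resting on compound 2, compound 3 and compound 4 alone. With hydrogen on that carbon, phenyl in place of acetyl on the ring nitrogen reads no change at the digits printed from compound 1 to compound 4 (within the scatter) and does not separate the two compounds.

No measurement here accounts for the large methyl step. Open, from the compounds shown here alone, is whether ethyl or methoxy at this carbon keeps the number of compound 3, and whether acetyl on the ring nitrogen matches phenyl with the methyl present.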